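Ring-nitrogen substituent changes in the succinimide series

The source may report more compounds than this note shows. Statements on the series, on what has been measured and on what is new or still open speak of the compounds shown alone.

The series shares one core, varied at the substituent on the amine nitrogen in a ring. Compound 1 `O=C1CC(c2ccccc2F)C(=O)N1CN1CCN(c2ccc(F)cc2)CC1` gives 30 mg/kg in a functional assay on the whole organism (strain CF-1 albino) with Mus musculus as the target, with a stated time of 4 h; a lower number here means that less compound is needed, a higher number that more compound is needed for the effect. Compound 3 `O=C1CC(c2ccccc2F)C(=O)N1CN1CCN(c2ncccn2)CC1` gives 100 mg/kg; the step of a 3.3-fold higher number from compound 1 to compound 3 (0.52 log units; beyond the scatter) is modest. Compound 2 `O=C1CC(c2ccccc2Br)C(=O)N1CN1CCN(c2ccccc2Cl)CC1` gives 300 mg/kg, the highest of the three numbers; compound 3 lies nearest to it and compound 1 furthest, both differences beyond the scatter.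

Compound 4 `O=C1CC(c2ccccc2Br)C(=O)N1CN1CCN(C2CCCCC2)CC1` is not yet measured. It differs from compound 2 by cyclohexyl in place of 2-chlorophenyl on an amine nitrogen in a ring. Among the measured compounds shown here, the only measured step at this position is a 3.3-fold higher number from compound 1 to compound 3 (0.52 log units; beyond the scatter), which exchanges one aromatic ring for another and gave a modest rise. For the measured compounds named here, no measured pair exchanges an aromatic ring for a non-aromatic one, so it is taken only as a sign that changes here move the number by a modest amount, with no firm direction. Compound 4 is therefore expected at 300 mg/kg, with a range from 100 mg/kg to 1000 mg/kg. The expected step is no change at the digits printed from compound 2 to compound 4 (within the scatter), within the scatter.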

Compound 4, minimum effective dose: 100 mg/kg
For compound 4 the middle estimate is 3.0-fold (0.48 log units) above the measured one; measured number inside the range.
By their numbers in this assay, from the lowest: compound 1; then compounds 3 and 4 (each within the scatter of the next); then compound 2.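

Cyclohexyl in place of 2-chlorophenyl gives a 3.0-fold lower number from compound 2 to compound 4 (0.48 log units; beyond the scatter) in this assay, the first measured exchange of an aromatic ring for a non-aromatic one on the amine nitrogen in a ring. The earlier step between two aromatic rings was a 3.3-fold higher number from compound 1 to compound 3 (0.52 log units; beyond the scatter), so changes at this position now show numbers moving in both directions, and an aromatic ring of carbon only is not needed here for the lower number. No measured property bears on this result.

The compounds shown do not separate the loss of the aromatic ring from the loss of the chlorine. On these data alone, it also remains open how a plain phenyl or an open chain such as hexyl would read on the core of compound 2, and whether cyclohexyl would give a step in the same direction on the core of compound 1.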